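Toward a pyridin-3-yl analogue: working notes on stability

This account rests on a few compounds, and the source may have more. Where it says the series, first, only, none or still open, it means among the compounds named here.

Values in an ADME assay on microsomes from liver (Rattus norvegicus) for metabolic stability, read by LC-MS, with a stated time of 30 min, tested at 0.5 uM; a lower number here means that less of the compound is left, a higher number that more of the compound is left:
- compound 1 `Oc1ccc(-c2nc(-c3csc(N=C4NCCCN4)n3)cs2)cc1`: 53%
- compound 2 `Oc1ccccc1-c1nc(-c2csc(N=C3NCCCN3)n2)cs1`: 38%

Compound 2 holds the lower of the two numbers, 38%. Compound 3 `c1cncc(-c2nc(-c3csc(N=C4NCCCN4)n3)cs2)c1` differs from compound 2 as follows: pyridin-3-yl in place of 2-hydroxyphenyl on an aromatic carbon. In words, pyridin-3-yl stands in place of 2-hydroxyphenyl on an aromatic carbon.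

Going by the values given here, only one measured step bears on this change: a number 15 percentage points lower from compound 1 to compound 2 (beyond the scatter). That modest step, beyond the scatter, swapped one hydroxyphenyl group for another at the same place. Among the compounds with values here, no measured compound carries pyridin-3-yl, so this step offers only a guide to size, and the direction is weakly supported. A modest upward move in this assay is expected, toward compound 1 at 53%. The expected step is a number 12 percentage points higher from compound 2 to compound 3 (beyond the scatter). In this assay, the estimated value for compound 3 is 50%, with an expected range of 28% to 72%.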

Compound 3, percent of the compound remaining: 19%
Estimate against measurement, compound 3: 31 percentage points above; measured number outside the range, below it.
By their numbers in this assay, from the lowest: compound 3; then compound 2; then compound 1.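

At this aromatic carbon, the change to pyridin-3-yl in this assay brings a number 19 percentage points lower from compound 2 to compound 3 (beyond the scatter), and measured against 4-hydroxyphenyl it brings a number 34 percentage points lower from compound 1 to compound 3 (beyond the scatter). Compound 3 therefore stands lowest of the three, with both of its steps beyond the scatter, so the number depends on which aromatic ring sits here and not only on where the hydroxy group sits on a phenyl ring. Nothing available explains why the number falls with this change.

From the compounds shown here alone, compound 3 loses the hydroxy group and gains a ring nitrogen in a single change, so the share of each in the step stays open. An unsubstituted phenyl at this carbon would separate the two, and a pyridin-3-yl bearing an amine or a carboxylic acid would show whether the low number can be moved.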